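Metabolic stability notes: from compound 1 toward compound 3

The compounds below may be only part of what the source reports. "The series", "measured", "known", "first", "only" and "open" are said of these compounds alone.

Measured so far in an ADME assay on cells (Hepatocyte, Rattus norvegicus) for metabolic stability; on this read-out higher numbers stand for fast clearance and lower numbers for slow clearance:
compound 1 `CN(C(=O)[C@H]1CN(S(=O)(=O)c2ccccc2)C[C@@H]1NC(=O)c1cc(-c2ccccc2Cl)on1)[C@H]1CCCNC1` gives 5.8 uL/min
compound 2 `CN(C(=O)[C@H]1CN(S(=O)(=O)c2ccccc2)C[C@@H]1N(C)C(=O)c1cc(-c2ccccc2Cl)on1)[C@H]1CCCNC1` gives 13 uL/min

Compound 1 holds the lowest number of the two; its nearest neighbour is compound 2, reached by a 2.2-fold higher number from compound 1 to compound 2 (0.35 log units; beyond the scatter).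

Compound 3 `CC(=O)N1CCC[C@H](NC(=O)[C@H]2CN(S(=O)(=O)c3ccccc3)C[C@@H]2NC(=O)c2cc(-c3ccccc3Cl)on2)C1` differs from compound 1 as follows: a group of 10 heavy atoms (7 carbon, 2 nitrogen, 1 oxygen; one six-membered non-aromatic ring with 1 hetero atom) in place of a group of 8 heavy atoms (6 carbon, 2 nitrogen; one six-membered non-aromatic ring with 1 hetero atom), on a carbonyl carbon. Within the data shown here, the only measured step, methyl in place of hydrogen on an amide-type nitrogen, sits at a different site and is of a different kind, so it bears on the new change only loosely; it shows that a single small change can move this assay by a modest but real amount. Among the measured compounds shown here, with no step of the same kind in hand, a modest shift, direction uncertain, is expected for compound 3, roughly a 1.4-fold higher number from compound 1 to compound 3 (0.14 log units; within the scatter). Compound 3 is therefore estimated at 8 uL/min, with a range from 3 uL/min to 20 uL/min.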

Compound 3, intrinsic clearance in a liver preparation (reported as CLH), per the amount of preparation that the assay uses: 196 uL/min
For compound 3 the middle estimate is 25-fold (1.39 log units) below the measured one, and the stated range ends below it.
By their numbers in this assay, from the lowest: compound 1; then compound 2; then compound 3.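

In this assay, among these compounds, this position on a carbonyl carbon proves highly sensitive to the group it carries, with a 34-fold higher number from compound 1 to compound 3 (1.53 log units; beyond the scatter); the step is large, whereas the one earlier step, at a different site, was modest. The size of this step comes from replacing one six-membered non-aromatic ring group with another of similar size, and the two groups match in hydrogen-bond donors, hydrogen-bond acceptors and net charge, so those counts do not separate compound 1 from compound 3. No measurement available here bears on the origin of this step.

The swap changes more than one feature of the group at once, so the step cannot be assigned to any single feature. From the compounds shown here alone, how a group carrying an open-chain amine or a carboxylic acid on this carbonyl carbon would read remains open.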